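Nitrile position shift: compound 2 to compound 4

This account rests on a few compounds, and the source may have more. Where it says the series, first, only, none or still open, it means among the compounds named here.

Three compounds have numbers in an assay on isolated protein for inhibition of Amine oxidase [flavin-containing] A (Homo sapiens), read by fluorescence; a higher number here means a weaker inhibitor, a lower number a stronger inhibitor. Compound 1 `N#Cc1cccc(/C=C/C(=O)c2cc(O)c(O)c([N+](=O)[O-])c2)c1` gives 58900 nM. Compound 3 `O=C(/C=C/c1ccco1)c1cc(O)c(O)c([N+](=O)[O-])c1` gives 60500 nM. Compound 2 `CC(=O)N1N=C(c2cc(O)c(O)c([N+](=O)[O-])c2)CC1c1ccc(C#N)cc1` gives 76600 nM, the highest of the three numbers, though its gaps to compound 3 and to compound 1 both fall within the usual scatter, so no ordering among the three can be read from these figures; all three sit in the same weak region.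

The step to compound 4 `CC(=O)N1N=C(c2cc(O)c(O)c([N+](=O)[O-])c2)CC1c1cccc(C#N)c1` is a single structural change: 3-cyanophenyl in place of 4-cyanophenyl on a saturated ring carbon. Among the measured compounds shown here, none of the measured compounds shows this kind of change on a shared core. For the measured compounds named here, compound 1 carries a 3-cyanophenyl and compound 2 a 4-cyanophenyl, but their cores differ as well, so those two values show only that both compounds land close together in this assay. No basis exists for expecting a step beyond the scatter in either direction. The estimate for compound 4 in this assay is 70000 nM, with a range from 30000 nM to 160000 nM. The implied step is expected to stay within the scatter, at a 1.1-fold lower number from compound 2 to compound 4 (0.04 log units; within the scatter).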

Compound 4, half-maximal inhibitory concentration: 70600 nM
Beside the measured number, compound 4's estimate is 1.0-fold (0.00 log units) below it, within the range that was stated.
By their numbers in this assay, from the lowest: compounds 1, 3, 4 and 2 (each within the scatter of the next).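

Moving the nitrile, with 3-cyanophenyl in place of 4-cyanophenyl on the saturated ring carbon, gives in this assay a 1.1-fold lower number from compound 2 to compound 4 (0.04 log units; within the scatter). Among the compounds shown here, this is the first reading of the nitrile position on a shared core, since compound 1 and compound 2 carry these two groups on different cores and so could not isolate the change. On this core, then, the two placements of the nitrile cannot be told apart in this assay, and no measurement on hand offers an account of this result.

On these data alone, only these two placements have been compared, so it remains open whether a different group at this aryl position, such as an amine or a carboxylic acid in place of the nitrile, would give a step beyond the scatter. Also open, as far as these compounds go, is whether the saturated ring carbon is equally indifferent when the acetyl group gives way to a longer chain, and whether the same nitrile shift reads alike on the core of compound 1.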